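Pyridinyl pyrimidine amines: sulfone to amide swap

The source may report more compounds than this note shows. Statements on the series, on what has been measured and on what is new or still open speak of the compounds shown alone.

Measured so far:
- compound 1, `c1ccc(-c2cc(NCC3CC3)ncn2)nc1`, 22000 nM in a functional assay on HEK293 cells for agonist activity at G-protein coupled receptor 39 (Homo sapiens), read by inositol phosphate accumulation; a higher number here means that more compound is needed for the effect, a lower number that less compound is needed
- compound 2, `CNc1nc(NCc2ccc(S(C)(=O)=O)cc2)cc(-c2ccccn2)n1`, 36 nM in this assay

Two compounds have numbers in this assay. Compound 2 stands at the lower of the two; the number for compound 1 is higher, and the gap between the two lies beyond the scatter. Both share the pyridinyl-substituted core, but they differ in several places at once, so nothing can be said about which of those differences carries the gap.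

Compound 3, `CNC(=O)c1ccc(CNc2cc(-c3ccccn3)nc(NC)n2)cc1`, has not yet been measured. It differs from compound 2 in one place: methylcarbamoyl in place of methylsulfonyl on an aromatic carbon. The change keeps the size of the group on the aromatic carbon and swaps one acceptor for a donor-plus-acceptor pair. Going by the values given here, no measured pair in this set shows such an exchange, so the direction of the step is unknown; a step within the scatter, or a modest one in either direction, is the expectation.

For compound 3 the expected step is a 1.7-fold higher number from compound 2 to compound 3 (0.22 log units; within the scatter), and the estimated value in this assay is 60 nM, within a range of 15 nM to 250 nM.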

Compound 3, half-maximal effective concentration: 30 nM
Beside the measured number, compound 3's estimate is 2.0-fold (0.30 log units) above it, and the stated range covers the measured number.
By their numbers in this assay, from the lowest: compounds 3 and 2 (each within the scatter of the next); then compound 1.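

In this assay, the step at the aromatic carbon para to a large group is a 1.2-fold lower number from compound 2 to compound 3 (0.08 log units; within the scatter), so this first exchange read at a single place shows methylsulfonyl and methylcarbamoyl standing level within the scatter. The exchange replaces a group with 0 hydrogen-bond donors and 2 hydrogen-bond acceptors by one with 1 hydrogen-bond donor and 1 hydrogen-bond acceptor, and in this one pair that difference leaves no readable mark on the number in this assay. No measurement shown here bears on why the two groups match.

Open, as far as these compounds go, is whether this level result extends to other groups on the same aromatic carbon, such as a carboxylic acid, a nitrile or an amine, or to a longer chain on the amide nitrogen in place of the methyl. Going by these compounds alone, also open is which of the several differences between compound 1 and the other two compounds carries the large gap in this assay, since no single-place step connects compound 1 to either of them.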